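From compound 3 to compound 4: a second chlorine

The source may hold more compounds than are shown below. What is called first, only, known or untested is meant among the compounds shown, and "the series" means these compounds.

Measured in an ADME assay on A549 cells (Homo sapiens) for cytotoxicity, read by resazurin assay, with a stated time of 48 h; a higher number here means that more compound is tolerated, a lower number that less compound is tolerated:
Compound 1 `CC(=O)Nc1ccc(NC(=O)c2cc(Cl)ccc2O)c(Cl)c1`: "not determined" (no result reported)
Compound 2 `CCCCCCC(C)Nc1ccc(NC(=O)c2cc(Cl)ccc2O)c(Cl)c1`: 23500 nM
Compound 3 `O=C(Nc1ccc(NCc2ccc(Cl)cc2)cc1Cl)c1cc(Cl)ccc1O`: 59700 nM

Of the two numbers available, the higher belongs to compound 3 at 59700 nM, and compound 1 offers none for comparison. Compound 4 `O=C(Nc1ccc(NCc2cc(Cl)cc(Cl)c2)cc1Cl)c1cc(Cl)ccc1O` differs from compound 3 in one place: 3,5-dichlorophenyl in place of 4-chlorophenyl on a saturated chain carbon bound to a nitrogen on an aromatic ring. Among the measured compounds shown here, the only measured step, a 2.5-fold higher number from compound 2 to compound 3 (0.40 log units; beyond the scatter), was modest and replaced 1-methylheptyl with 4-chlorobenzyl, a different kind of exchange. It gives no direction for this change, so no step beyond the scatter is expected in this assay. The estimate corresponds to an expected 1.3-fold lower number from compound 3 to compound 4 (0.12 log units; within the scatter). For compound 4 the expected value is 45000 nM, with an estimated range of 18000 nM to 100000 nM.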

Compound 4, half-maximal cytotoxic concentration: 13300 nM
Compound 4: middle estimate off by 3.4-fold (0.53 log units), on the high side, outside the stated range (below it).
By their numbers in this assay, from the lowest: compounds 4 and 2 (each within the scatter of the next); then compound 3.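

In this assay, the 4-chlorobenzyl group's edge did not survive the change on this nitrogen substituent: 3,5-dichlorophenyl in place of 4-chlorophenyl gave a clear step (a 4.5-fold lower number from compound 3 to compound 4 (0.65 log units; beyond the scatter)). The ring on the saturated chain carbon is therefore not indifferent to its chlorines, and 3,5-dichlorobenzyl no longer stands apart from 1-methylheptyl (a 1.8-fold lower number from compound 2 to compound 4 (0.25 log units; within the scatter)). Nothing available explains this step.

Open, on these data alone, is how an unsubstituted benzyl or a 3,5-difluorobenzyl would read here, and so whether the chlorine count or the chlorine placement matters.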